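The source may report more compounds than this note shows. Statements on the series, on what has been measured and on what is new or still open speak of the compounds shown alone.

Measured so far in a toxicity assay on CHO-K1 cells (Cricetulus griseus) for cytotoxicity, read by MTT assay, with a stated time of 48 h; on this read-out lower numbers stand for stronger inhibition and higher numbers for weaker inhibition:
- compound 1 `COCCCN1C(/C=C/c2ccc(O)cc2)=CC(=O)CC1c1ccc(O)cc1`: > 100000 nM
- compound 2 `O=C(/C=C(/C=C/c1ccc(O)cc1)NCCCO)/C=C/c1ccc(O)cc1`: 39100 nM

Compound 1 gives > 100000 nM, which is a limit of the assay and not a number. For the measured compounds named here, compound 2, at 39100 nM, holds the only true number in this assay.

Next comes compound 3 `O=C(/C=C(/C=C/c1ccc(O)cc1)NCCO)/C=C/c1ccc(O)cc1`, with the change hydroxy in place of hydroxymethyl on a saturated chain carbon, two bonds along the chain from an amine nitrogen. Going by the values given here, no measured step covers this change. The expected step of a 1.0-fold higher number from compound 2 to compound 3 (0.01 log units; within the scatter) is none beyond the scatter, in either direction. Compound 3 is estimated at 40000 nM, with an expected range of 15000 nM to 100000 nM.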

Compound 3, half-maximal inhibitory concentration: 66000 nM
Compound 3: middle estimate off by 1.7-fold (0.22 log units), on the low side; low and high end bracket the measured number.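

In this assay, going from (3-hydroxypropyl)amino to (2-hydroxyethyl)amino gives a 1.7-fold higher number from compound 2 to compound 3 (0.23 log units; within the scatter), so this first reading of chain length at this position shows no change beyond the scatter. It rests on a single pair of true numbers. Compound 1 remains a limit of the assay and not a number: the limit of > 100000 nM in this assay, at which 1 of the 3 values shown sits.

Still open, from the compounds shown here alone, is whether a longer chain on this nitrogen stays within the scatter. Also open, going by these compounds, is whether an amine or a carboxylic acid in place of the hydroxy moves the number beyond it.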